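Clearance notes on the step to compound 3

The source may hold more compounds than are shown below. What is called first, only, known or untested is meant among the compounds shown, and "the series" means these compounds.

In an ADME assay on microsomes from liver (Homo sapiens) for metabolic stability, read by LC-MS, using NADPH, with stated times of 5 min and 30 min, tested at 1 uM (a lower number here means slower removal, a higher number faster removal of the compound), the measured values are
compound 1 `CN(C)C(=O)c1cc(-c2cnc(NCc3c(F)ccc4c3CCO4)c3cn[nH]c(=O)c23)n(C)n1` (21 mL.min-1.g-1)
compound 2 `CNC(=O)c1ncc(-c2cnc(NCc3c(F)ccc4c3CCO4)c3cn[nH]c(=O)c23)n1C` (24 mL.min-1.g-1)

Compound 2 and compound 1 lie within the scatter of each other, so compound 2 does not stand apart. Compound 3 `CN(c1ccn(C)n1)c1cnc(NCc2c(F)ccc3c2CCO3)c2cn[nH]c(=O)c12` carries methyl(1-methyl-1H-pyrazol-3-yl)amino in place of 1-methyl-2-(methylcarbamoyl)-1H-imidazol-5-yl on an aromatic carbon. For the measured compounds named here, the only measured step (a 1.1-fold higher number from compound 1 to compound 2 (0.06 log units; within the scatter)) exchanges one carbamoyl-bearing ring for another and stays within the scatter. Going by the values given here, it is weak guidance, as no measured compound lacks a carbamoyl group. No change beyond the scatter is expected, and the estimated step is a 1.2-fold higher number from compound 2 to compound 3 (0.07 log units; within the scatter) (slightly upward). For compound 3 the estimated value is 28 mL.min-1.g-1 (expected range 12 mL.min-1.g-1 to 60 mL.min-1.g-1).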

Compound 3, intrinsic clearance in microsomes: 62 mL.min-1.g-1
The estimate for compound 3 lay 2.2-fold (0.35 log units) below the measured number; measured number outside the range, above it.
By their numbers in this assay, from the lowest: compounds 1 and 2 (each within the scatter of the next); then compound 3.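

At this position, on an aromatic carbon two atoms from the ring nitrogen, methyl(1-methyl-1H-pyrazol-3-yl)amino gives a 2.6-fold higher number from compound 2 to compound 3 (0.41 log units; beyond the scatter) and a 3.0-fold higher number from compound 1 to compound 3 (0.47 log units; beyond the scatter) in this assay. For the compounds shown here, these are the first steps beyond the scatter, so this position can shift clearance, and compound 3, the only compound here without a carbamoyl group, stands highest. No measurement on hand accounts for the rise.

Loss of the carbamoyl group and arrival of the methylamino link occur together, so their contributions remain unseparated. A 1-methyl-1H-pyrazol-3-yl group attached directly, or a morpholine at this position, would bear on that question.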